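The source may report more compounds than this note shows. Statements on the series, on what has been measured and on what is new or still open speak of the compounds shown alone.

In a functional assay on LNCaP cells (Homo sapiens) for antiproliferative activity (a lower number here means a stronger inhibitor, a higher number a weaker inhibitor), three compounds sharing one core have been measured. Compound 1 `Cn1ncc(Cl)c1-c1cc(C(=O)N[C@@H]2CN[C@H](CCN3CCC(O)CC3)C[C@H]2c2ccc(Cl)c(Cl)c2)oc1Cl` gives 1140 nM, compound 2 `Cn1ncc(Cl)c1-c1cc(C(=O)N[C@@H]2CN[C@H](CC(N)=O)C[C@H]2c2ccc(Cl)c(Cl)c2)oc1Cl` gives 160 nM, and compound 3 `Cn1ncc(Cl)c1-c1cc(C(=O)N[C@@H]2CN[C@H](CC(=O)O)C[C@H]2c2ccc(Cl)c(Cl)c2)oc1Cl` gives 640 nM. Two steps fix the place of compound 3: a 1.8-fold lower number from compound 1 to compound 3 (0.25 log units; within the scatter) shows no real separation, while a 4.0-fold higher number from compound 2 to compound 3 (0.60 log units; beyond the scatter) does.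

Compound 4 `Cn1ncc(Cl)c1-c1cc(C(=O)N[C@@H]2CN[C@H](CC(=O)NCC(O)CO)C[C@H]2c2ccc(Cl)c(Cl)c2)oc1Cl` carries (2,3-dihydroxypropyl)amino in place of hydroxy on a carbonyl carbon. The most relevant measurement concerns that same carbonyl carbon: hydroxy in place of amino gave a 4.0-fold higher number from compound 2 to compound 3 (0.60 log units; beyond the scatter), so going back to an amide points towards a lower number. Within the data shown here, a second step, a 7.1-fold lower number from compound 1 to compound 2 (0.85 log units; beyond the scatter), shows that the side chain can move the number by a modest amount, but no measured compound carries this substituted amide, so only part of the gain is assumed. The expected change is a 2.3-fold lower number from compound 3 to compound 4 (0.36 log units; beyond the scatter), a modest step towards a lower number in this assay. For compound 4 the estimated value is 280 nM, with an expected range of 90 nM to 850 nM.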

Compound 4, half-maximal inhibitory concentration: 660 nM
Compound 4: the middle estimate sits 2.4-fold (0.37 log units) below what was measured, and the stated range covers the measured number.
By their numbers in this assay, from the lowest: compound 2; then compounds 3, 4 and 1 (each within the scatter of the next).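

In this assay, an amide on this carbonyl carbon does not by itself give the lower number: a 1.0-fold higher number from compound 3 to compound 4 (0.01 log units; within the scatter), so the gain seen with the plain amide does not carry over to (2,3-dihydroxypropyl)amino. Putting 2,3-dihydroxypropyl on the amide-type nitrogen gives a 4.1-fold higher number from compound 2 to compound 4 (0.62 log units; beyond the scatter), which sets the unsubstituted carbamoyl of compound 2 apart, while a 1.7-fold lower number from compound 1 to compound 4 (0.24 log units; within the scatter) places compound 4 level with the (4-hydroxypiperidin-1-yl)methyl side chain as well. No evidence is available to explain this result.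

The compounds shown leave open whether a single methyl group on that nitrogen would keep the number of compound 2 or raise it. They also leave open how a 2-hydroxyethyl chain or a chain ending in an amine would behave there.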